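Amino in Place of Methyl: An Expected Cytotoxicity Step

The source may hold more compounds than are shown below. What is called first, only, known or untested is meant among the compounds shown, and "the series" means these compounds.

In a functional assay on SW480 cells (Homo sapiens) for cytotoxicity, read by MTT assay, with a stated time of 72 h (on this read-out lower numbers stand for stronger inhibition and higher numbers for weaker inhibition), three compounds have been measured so far. Compound 2 `Cc1nnc(SCc2coc3ccc(Cl)cc3c2=O)s1` gives 3200 nM in this assay. Compound 1 `Cc1nnc(Sc2c(C)oc3ccccc3c2=O)o1` does not give a number at all in this assay but only a limit, > 50000 nM. Compound 3 `Cc1nnc(SCc2cc(=O)c3ccccc3o2)s1` likewise gives only a limit in this assay, > 25000 nM. Compound 3 thus stands at the limit of > 25000 nM in this assay, at which 1 of the 3 values shown sits, so its true value is not known and it can only be said that it lies past that point. Compound 1 stands at the limit of > 50000 nM in this assay, at which 1 of the 3 values shown sits, again without a number.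

Compound 4 `Nc1nnc(SCc2cc(=O)c3ccccc3o2)s1` is not yet measured. It differs from compound 3 in one place: amino in place of methyl on an aromatic carbon. For the measured compounds named here, no pair of measured compounds shares this change, so the size of the step cannot be read from any measured pair, and compound 3 itself gives only a limit as a starting point. The expected step is therefore a step that the limit leaves unreadable from compound 3 to compound 4, which means no change beyond the usual scatter, in either direction. Compound 4 is estimated at 30000 nM in this assay, with a range from 8000 nM to 100000 nM, and it may well again yield only a limit.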

Compound 4, half-maximal inhibitory concentration: > 25000 nM
Compound 4 was reported as a limit; the forecaster's own chance of this, stated with the estimate: 60%; the middle value lies beyond the limit too.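

Compound 3 and compound 4 each give only a limit, not a number, in this assay, so the step from methyl to amino between them cannot be read. The compounds shown leave open whether amino in place of methyl on an aromatic carbon changes cytotoxicity on this core at all, in either direction.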